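A few compounds are considered here, and "the series" means these few. Any claim that something is new, unique, unknown or untested is made for them only; others in the source may bear on it.

The three measured compounds share one core and differ only in the group on a saturated chain carbon bound to an amine nitrogen in a ring. In an assay on Sf21 cells for inhibition of high affinity nerve growth factor receptor (Homo sapiens), read by HTRF, with a stated time of 30 min, in the presence of a further agent that is not named here (a lower number here means a stronger inhibitor, a higher number a weaker inhibitor), compound 1 `CC1(C)c2[nH]nc(NC(=O)c3ccccc3)c2CN1Cc1ccccc1` gives 1240 nM. In this assay compound 2 `CC1(C)c2[nH]nc(NC(=O)c3ccccc3)c2CN1Cc1cccc(I)c1` gives 1360 nM, the highest number of the three; its nearest is compound 1, with a 1.1-fold higher number from compound 1 to compound 2 (0.04 log units; within the scatter), and its furthest is compound 3 `CC1(C)c2[nH]nc(NC(=O)c3ccccc3)c2CN1Cc1cccc(Cl)c1`, which in this assay gives 670 nM, a step of a 2.0-fold lower number from compound 2 to compound 3 (0.31 log units; beyond the scatter). A further step is a 1.9-fold lower number from compound 1 to compound 3 (0.27 log units; within the scatter).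

Compound 4 `Cc1ccc(CN2Cc3c(NC(=O)c4ccccc4)n[nH]c3C2(C)C)cc1F` is reached from compound 2 by 3-fluoro-4-methylphenyl in place of 3-iodophenyl on a saturated chain carbon bound to an amine nitrogen in a ring. Among the measured compounds shown here, the steps that bear on this change are those altering the same aromatic ring, a 1.1-fold higher number from compound 1 to compound 2 (0.04 log units; within the scatter) and a 2.0-fold lower number from compound 2 to compound 3 (0.31 log units; beyond the scatter), neither of them more than modest. On that basis, in this assay a step of a 1.5-fold lower number from compound 2 to compound 4 (0.18 log units; within the scatter) is expected, small and possibly not beyond the scatter. Compound 4 is estimated at 900 nM, within 400 nM to 2000 nM.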

Compound 4, half-maximal inhibitory concentration: 940 nM
Beside the measured number, compound 4's estimate is 1.0-fold (0.02 log units) below it; the measured number falls inside the stated range.
By their numbers in this assay, from the lowest: compounds 3, 4, 1 and 2 (each within the scatter of the next, the first and the last beyond it).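

In this assay the 3-fluoro-4-methylphenyl group, the first here to carry two groups on its aromatic ring, gives three small steps (a 1.4-fold lower number from compound 2 to compound 4 (0.16 log units; within the scatter); a 1.4-fold higher number from compound 3 to compound 4 (0.15 log units; within the scatter); a 1.3-fold lower number from compound 1 to compound 4 (0.12 log units; within the scatter)), each within the scatter. At this place, on a saturated chain carbon bound to an amine nitrogen in a ring, a fluoro and a methyl together are therefore tolerated in this compound without a step beyond the scatter from the phenyl, 3-iodophenyl or 3-chlorophenyl compounds. Compound 4 adds no wider gap, and the only step beyond the scatter remains a 2.0-fold lower number from compound 2 to compound 3 (0.31 log units; beyond the scatter) among these compounds.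

The compounds shown leave open how far the fluoro and the methyl each count alone, and whether a morpholine, a carboxylic acid or a longer chain in place of 3-fluoro-4-methylphenyl would move the number further. Nothing given here accounts for these small differences.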